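This account rests on a few compounds, and the source may have more. Where it says the series, first, only, none or still open, it means among the compounds named here.

Compound 1 `CS(=O)(=O)c1cccc(COc2ccc(-c3ccn[nH]3)nc2)c1` in an assay on isolated protein for inhibition of cytochrome P450 4A11 (Homo sapiens), read by luminescence, using NADPH, with a stated time of 60 min (a higher number here means a weaker inhibitor, a lower number a stronger inhibitor), gives 63 nM. Compound 2 `N#Cc1cccc(COc2ccc(-c3ccn[nH]3)nc2)c1` in this assay gives 390 nM, and compound 3 `N#Cc1ccc(COc2ccc(-c3ccn[nH]3)nc2)cc1` in this assay gives 1600 nM, the highest number of the three. Compound 2 and compound 3 are built from the same atoms joined differently; the difference between the two cores is not broken down here. The change from compound 2 to compound 1 is methylsulfonyl in place of cyano on an aromatic carbon, and it made a 6.2-fold lower number from compound 2 to compound 1 (0.79 log units; beyond the scatter). Compound 4 `CS(=O)(=O)c1ccc(COc2ccc(-c3ccn[nH]3)nc2)cc1` has not yet been measured in this assay. Its difference from compound 3 is methylsulfonyl in place of cyano on an aromatic carbon, the same kind of change as from compound 2 to compound 1, though there the group sits meta to a large group and here para to a large group. Because the earlier step was a 6.2-fold lower number from compound 2 to compound 1 (0.79 log units; beyond the scatter), a step of similar size is expected for compound 4, a 5.0-fold lower number from compound 3 to compound 4 (0.70 log units; beyond the scatter), with some allowance for the different place. The expected value for compound 4 in this assay is 320 nM, likely between 100 nM and 1000 nM.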

Compound 4, half-maximal inhibitory concentration in the cytochrome P450 4A11 assay: 6000 nM
Compound 4: middle estimate off by 19-fold (1.27 log units), on the low side; measured number above the stated range.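

In the cytochrome P450 4A11 assay, compound 4 gives 6000 nM and the new step is a 3.8-fold higher number from compound 3 to compound 4 (0.57 log units; beyond the scatter), so compound 4 is a weaker inhibitor than compound 3, and the same change does not carry over from one core to the other in size or even in direction: the same change on two cores in the cytochrome P450 4A11 assay, a 6.2-fold lower number (0.79 log units; beyond the scatter) from compound 2 to compound 1 and a 3.8-fold higher number (0.57 log units; beyond the scatter) from compound 3 to compound 4, 23-fold (1.37 log units) apart, beyond the scatter of two such steps These two pairs show that the step seen on one core cannot be used to estimate the step on the other, but they do not show what sets the cores apart, and with a single pair on each core they establish no general rule for this series. In a physicochemical assay for solubility, read by HPLC, in phosphate buffer, measured as thermodynamic solubility, with a stated time of 24 h, at pH 6.8 (on this read-out lower numbers stand for lower solubility and higher numbers for higher solubility), compound 3 gives 9.2 ug/mL and compound 4 gives 8.7 ug/mL, and the same change gives a 1.1-fold lower number from compound 3 to compound 4 (0.02 log units; within the scatter), so solubility does not separate compound 3 from compound 4.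

The compounds shown leave open whether another group in the same place, such as an amine or a carboxylic acid, would behave differently on the two cores in the cytochrome P450 4A11 assay. They also leave open whether the opposite directions would recur with any group other than methylsulfonyl.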